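This account rests on a few compounds, and the source may have more. Where it says the series, first, only, none or still open, it means among the compounds named here.

Measured compounds:
Compound 1 `O=C(C1CC(F)(F)C1)N1CCc2nc(C#Cc3cccc(F)c3)sc2C1`: > 10000 nM
Compound 2 `CC(C)S(=O)(=O)N1Cc2nc(C#Cc3ccccc3)sc2C1`: 140 nM
Compound 3 `O=S(=O)(C1CC1)N1CCc2nc(C#Cc3ccccc3)sc2C1`: 34 nM

All three were tested in an assay on HEK293 cells for negative allosteric modulation of metabotropic glutamate receptor 5 (Homo sapiens), read by FLIPR, with a stated time of 1 h; a lower number here means a stronger inhibitor, a higher number a weaker inhibitor. For compound 1 the result is only a limit of the assay, > 10000 nM, not a measured number; one of the three values shown is such a limit (the limit of > 10000 nM in this assay, at which 1 of the 3 values shown sits). Among the two real numbers, compound 2, with 140 nM, stands as the higher of the pair, while compound 3 gives 34 nM; the gap between those two is beyond the usual scatter. Compound 2 and compound 3 differ in more than one place, so that gap cannot be tied to a single change.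

The compound not yet measured is compound 4 `O=S(=O)(C1CCCCC1)N1Cc2nc(C#Cc3ccccc3)sc2C1`. It differs from compound 2 in one place only: cyclohexyl in place of isopropyl on a sulfonyl sulfur. Among the compounds with values here, no measured pair shows exactly this change, so its effect on the half-maximal inhibitory concentration cannot be read from the data. Both groups are saturated carbon, and the expectation is a small step, if any, most likely toward a somewhat lower number. Compound 4 is expected to give about 100 nM, with a plausible range from 25 nM to 400 nM, which corresponds to an expected step of a 1.4-fold lower number from compound 2 to compound 4 (0.15 log units; within the scatter).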

Compound 4, half-maximal inhibitory concentration: > 10000 nM
Compound 4 ended at the assay's limit; the forecaster's own chance of this, stated with the estimate: 5%; middle value at least 100-fold (2.00 log units) from the limit.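

In this assay the sulfonyl sulfur does not accept every saturated carbon group equally, as cyclohexyl in place of isopropyl gives an at least 71-fold higher number from compound 2 to compound 4 (1.85 log units; beyond the scatter). Within the data shown here, the earlier compounds offered no single change at this place, so this is the first direct reading of it: the swap brings more carbon and a ring, with no hydrogen-bond donors or acceptors entering or leaving, and that alone separates a measurable inhibitor from a compound with no measured number. For compound 4 the value > 10000 nM is a limit of the assay and not a number, so the step has no upper end, because the true value of compound 4 lies out of reach: the limit of > 10000 nM in this assay, at which 2 of the 4 values shown sit.

Going by these compounds, it stays open whether a cyclopentyl or a tert-butyl group on this sulfonyl sulfur would hold a value close to that of compound 2 or would already fall to the limit, so the point where the loss sets in is unknown. Also open, on these data alone, is whether a smaller methyl group, or a ring carrying an oxygen such as tetrahydropyranyl, would give a lower number than compound 2 does.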